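The source may hold more compounds than are shown below. What is called first, only, known or untested is meant among the compounds shown, and "the series" means these compounds.

Of the compounds shown here, two sharing one core have been tested in a functional assay on UO-31 cells (Homo sapiens) for inhibition, read by sulforhodamine B assay, with a stated time of 48 h, tested at 10 uM; a higher number here means more inhibition at the concentration tested (going by the name of the read-out), a lower number less inhibition. Compound 1 `Brc1cn2ccnc2c(-c2ccc3ncn(C4CCCCC4)c3c2)n1` gives 37.6% in this assay. Compound 2 `CCc1ccc(-c2cn3ccnc3c(-c3ccc4ncn(Cc5ccccc5)c4c3)n2)cc1` gives 57.9% in this assay, the higher of the two numbers, and the gap to compound 1 lies beyond the usual scatter of this kind of measurement, so compound 2 stands clearly above compound 1. Going by the values given here, because the two compounds differ in more than one place, the numbers show only that compound 2 inhibits more strongly, not which part of the structure is responsible.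

Compound 3 `Cc1cccc(-c2cn3ccnc3c(-c3ccc4ncn(Cc5ccccc5)c4c3)n2)c1` has not yet been measured. It differs from compound 2 in a single place: 3-methylphenyl in place of 4-ethylphenyl on an aromatic carbon. Among the compounds with values here, no measured pair shows what exchanging a 4-ethylphenyl for a 3-methylphenyl does in this assay, so there is no direct guide from the data. Since both groups are single six-membered aromatic rings of carbon bearing a small carbon chain, the step of a number 7.9 percentage points lower from compound 2 to compound 3 (within the scatter) is expected to be small, most likely within the scatter. Compound 3 is therefore estimated at 50%, within a range from 30% to 68%.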

Compound 3, a percentage reported as inhibition, at one concentration (the size of the read-out at that concentration, not a potency): 41.7%
Beside the measured number, compound 3's estimate is 8.3 percentage points above it; the range from low to high includes it.
By their numbers in this assay, from the lowest: compounds 1 and 3 (each within the scatter of the next); then compound 2.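

In this assay, going by these compounds alone, exchanging 4-ethylphenyl for 3-methylphenyl on this aromatic carbon of the shared core gives a number 16.2 percentage points lower from compound 2 to compound 3 (beyond the scatter), the first comparison here in which only one place changes. The number therefore responds to a small edit at this position: both groups have one six-membered aromatic ring of carbon only, no hydrogen-bond donors or acceptors and no net charge, and they differ by a single carbon. Nothing measured here explains why the number drops at this position.

The exchange alters two things at once, the length of the carbon chain and where it stands on the phenyl ring, so the compounds shown cannot say which of the two matters, or whether both do; a 4-methylphenyl or a 3-ethylphenyl group at this position would separate them. They also leave open what an unsubstituted phenyl, a longer chain such as 4-butylphenyl, or a phenyl ring carrying an amine or a carboxylic acid would do here.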